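A few compounds are considered here, and "the series" means these few. Any claim that something is new, unique, unknown or untested is made for them only; others in the source may bear on it.

Working notes on the series. Compound 1 `C[C@@H]1CN(c2sc(C(F)(F)F)nc2-c2nc3ccccc3[nH]2)CCN1C(=O)Cn1cccn1` in a functional assay on Venous blood for antagonist activity at C-X-C chemokine receptor type 3 (Homo sapiens), read by flow cytometry, with a stated time of 30 min, in the presence of a further agent that is not named here (a lower number here means a stronger inhibitor, a higher number a weaker inhibitor), gives 191 nM. Within the data shown here, compound 2 `C[C@@H]1CN(c2sc(C(F)(F)F)nc2-c2nc3ccccc3[nH]2)CCN1C(=O)Cn1cc(Cl)cn1` in this assay gives 251 nM, the higher of the two numbers so far, though the single step of a 1.3-fold higher number from compound 1 to compound 2 (0.12 log units; within the scatter) stays within the scatter, so the two compounds cannot be ordered. Compound 3 `C[C@@H]1CN(c2sc(C(F)(F)F)nc2-c2nc3ccccc3[nH]2)CCN1C(=O)Cn1cnc2c1CCN(C)C2` remains to be measured in this assay. The change from compound 2 to compound 3 is a group of 10 heavy atoms (7 carbon, 3 nitrogen; one five-membered aromatic ring with 2 hetero atoms, one six-membered non-aromatic ring with 1 hetero atom) in place of a group of 6 heavy atoms (3 carbon, 2 nitrogen, 1 chlorine; one five-membered aromatic ring with 2 hetero atoms), on a saturated chain carbon bound to a carbonyl carbon. Among the measured compounds shown here, the only measured step, from compound 1 to compound 2, concerns a chloro in place of hydrogen on that same pyrazole and bears only loosely on this larger replacement; it gave no shift beyond the scatter. For the measured compounds named here, no measured step covers an exchange of the whole ring group at this position, so the expectation for compound 3 is anchored on compound 2 with a wide range. Compound 3 is expected to give about 250 nM in this assay, between 80 nM and 800 nM, a step of a 1.0-fold lower number from compound 2 to compound 3 (0.00 log units; within the scatter) from compound 2 that is estimated to stay within the scatter.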

Compound 3, half-maximal inhibitory concentration: 135 nM
Compound 3: middle estimate off by 1.9-fold (0.27 log units), on the high side, and the stated range covers the measured number.
By their numbers in this assay, from the lowest: compounds 3, 1 and 2 (each within the scatter of the next).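

In this assay, the whole group on the saturated chain carbon bound to a carbonyl carbon can be exchanged for one with an added six-membered non-aromatic ring, and the number stays within the scatter: a 1.9-fold lower number from compound 2 to compound 3 (0.27 log units; within the scatter), and a 1.4-fold lower number from compound 1 to compound 3 (0.15 log units; within the scatter). The position therefore accepts a replacement of 10 heavy atoms, a far larger change than the chloro on the pyrazole, with no shift that can be read. Nothing available bears on why the numbers stay this close.

All three groups shown contain a five-membered aromatic ring with 2 hetero atoms, so it remains open whether a dimethylamino group, a carboxylic acid or an open alkyl chain on the same carbon would hold the number. As far as these compounds go, the role of the methyl on the non-aromatic ring of compound 3 is also open.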